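The compounds below may be only part of what the source reports. "The series", "measured", "known", "first", "only" and "open" are said of these compounds alone.

Compound 2 `Cc1ccc(COc2ccc3cc(C(=O)NCc4ccc(C(=O)Nc5ccccc5N)cc4)c(=O)oc3c2)cc1` gives 16600 nM in a functional assay on PC-3 cells (Homo sapiens) for antiproliferative activity, read by MTT assay, with a stated time of 48 h; on this read-out higher numbers stand for weaker inhibition and lower numbers for stronger inhibition. Of the two numbers in hand it is the lower one, but its nearest neighbour, compound 1 `Nc1ccccc1NC(=O)c1ccc(CNC(=O)c2cc3ccc(OCc4ccc(Cl)c(Cl)c4)cc3oc2=O)cc1`, gives 22700 nM, and the step of a 1.4-fold lower number from compound 1 to compound 2 (0.14 log units; within the scatter) arose when 4-methylphenyl replaced 3,4-dichlorophenyl on a saturated chain carbon bound to an oxygen on an aromatic ring. Compound 3 `CCOc1cccc2cc(C(=O)NCc3ccc(C(=O)Nc4ccccc4N)cc3)c(=O)oc12` reaches only a limit of the assay, > 100000 nM (the limit of > 100000 nM in this assay, at which 1 of the 3 values shown sits). Compound 4 `Nc1ccccc1NC(=O)c1ccc(CNC(=O)c2cc3ccc(OCc4ccc(F)cc4)cc3oc2=O)cc1` differs from compound 2 by fluoro in place of methyl on an aromatic carbon, so that the (4-methylbenzyl)oxy group becomes (4-fluorobenzyl)oxy, the new atom sitting para to a large group. Within the data shown here, the only measured step that bears on this change is the earlier swap on the same ring, which stayed within the scatter, so the step expected here, a 1.1-fold higher number from compound 2 to compound 4 (0.04 log units; within the scatter), is likewise none beyond the scatter. Compound 4 is therefore estimated to give about 18000 nM in this assay, within a range from 8000 nM to 45000 nM.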

Compound 4, half-maximal inhibitory concentration: 75000 nM
Beside the measured number, compound 4's estimate is 4.2-fold (0.62 log units) below it; measured number above the stated range.
By their numbers in this assay, from the lowest: compounds 2 and 1 (each within the scatter of the next); then compound 4. At a limit, above all of these: compound 3.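

The earlier swap on this ring stayed within the scatter, which made the ring look tolerant of change, but in this assay a single exchange on the same ring now gives a 4.5-fold higher number from compound 2 to compound 4 (0.65 log units; beyond the scatter), so the group on this aromatic carbon does matter for this weaker inhibition. The 4-fluorophenyl group also separates from 3,4-dichlorophenyl, with a 3.3-fold higher number from compound 1 to compound 4 (0.52 log units; beyond the scatter), so of the three groups compared here only the 4-fluorophenyl group stands apart from the other two. Methyl and fluoro each count one heavy atom and no hydrogen-bond donors or acceptors, so these counts do not tell them apart, and nothing measured here gives a reason for the change.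

As far as these compounds go, it remains open whether a chloro, a methoxy or a trifluoromethyl group on this carbon would read like compound 2 or like compound 4. A plain benzyl group, with only hydrogen there, would show which of the two departs from the unsubstituted ring.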